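Swapping Butylsulfanyl for Cyclopentylamino on a Shared Core

The source may report more compounds than this note shows. Statements on the series, on what has been measured and on what is new or still open speak of the compounds shown alone.

Compound 1, `CCCCSc1nc(N)nc2c1ncn2/C=C1/CC1(CO)CO`, is the starting point. In an ADME assay on CCRF-HSB-2 cells (Homo sapiens) for cytotoxicity, with a stated time of 7 days (a higher number here means that more compound is tolerated, a lower number that less compound is tolerated), compound 1 gives 89000 nM, the highest of the two plain numbers in this set. Its nearest neighbour is compound 3, `CCCCCCSc1nc(N)nc2c1ncn2/C=C1/CC1(CO)CO`, which gives 60000 nM in this assay; the step of a 1.5-fold lower number from compound 1 to compound 3 (0.17 log units; within the scatter) separates them. Compound 2, `Nc1nc(NC2CCCCC2)c2ncn(/C=C3/CC3(CO)CO)c2n1`, carries a cyclohexylamino group in place of the butylsulfanyl of compound 1, and in this assay compound 2 is reported only as a limit, > 20000 nM. That is the point described by the limit of > 20000 nM in this assay, at which 1 of the 3 values shown sits. The steps a step that the limit leaves unreadable from compound 1 to compound 2 and a step that the limit leaves unreadable from compound 2 to compound 3 therefore cannot be read in size or direction.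

Compound 4, `Nc1nc(NC2CCCC2)c2ncn(/C=C3/CC3(CO)CO)c2n1`, makes a closely related change: cyclopentylamino in place of butylsulfanyl on an aromatic carbon. For the measured compounds named here, the only measured step that bears on this change is the one from compound 1 to compound 2, and its limit leaves it unreadable; the step from compound 1 to compound 3 lies within the scatter. No reading beyond the scatter is available in either direction, so the expectation for compound 4 is a value in the same region as compound 1, with wide uncertainty. The expected step is a 2.0-fold lower number from compound 1 to compound 4 (0.30 log units; within the scatter). Compound 4 is estimated at 45000 nM, ranging from 15000 nM to 140000 nM.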

Compound 4, half-maximal cytotoxic concentration: > 20000 nM
Compound 4 gave a limit, no number; the forecaster's own chance of this, stated with the estimate: 35%; the middle value does not contradict the limit.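

Compound 4 is reported only as a limit, not a number, so its steps to compound 1, compound 2 and compound 3 cannot be read in size or direction: the limit of > 20000 nM in this assay, at which 2 of the 4 values shown sit.

The compounds shown leave open whether cyclopentylamino or cyclohexylamino in place of butylsulfanyl changes the tolerated concentration at all, and whether compound 2 and compound 4 differ.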